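The source may report more compounds than this note shows. Statements on the series, on what has been measured and on what is new or still open speak of the compounds shown alone.

Going by the values given here, in a functional assay on A549 cells (Homo sapiens) for cytotoxicity, read by MTT assay, with a stated time of 24 h (on this read-out higher numbers stand for weaker inhibition and lower numbers for stronger inhibition), compound 1 (`COc1cc(/C=C(\C#N)C(=O)N/N=C(\C)c2c(O)c3ccc(O)cc3oc2=O)ccc1O`) gives 12600 nM and sits level, within the scatter, with compound 2 (`COc1ccc(/C=C(\C#N)C(=O)N/N=C(\C)c2c(O)c3ccc(O)cc3oc2=O)cc1OC`) at 14300 nM on the only numbers so far. Compound 3 (`COc1ccc(/C=C(\C#N)C(=O)N/N=C(\C)c2c(O)c3ccc(O)cc3oc2=O)cc1`) is still unmeasured and differs from compound 1 by 4-methoxyphenyl in place of 4-hydroxy-3-methoxyphenyl on a double-bonded chain carbon bound to a double-bonded chain carbon with 4-methoxyphenyl in place of 4-hydroxy-3-methoxyphenyl. Among the compounds with values here, the one measured step that bears on this is a 1.1-fold higher number from compound 1 to compound 2 (0.05 log units; within the scatter) for methyl in place of hydrogen on an oxygen on an aromatic ring, which alters the same hydroxy without removing it. The estimated step is therefore a 1.1-fold higher number from compound 1 to compound 3 (0.05 log units; within the scatter) and no shift in either direction beyond the scatter is expected. In this assay compound 3 is expected at 14000 nM (estimated range 7000 nM to 28000 nM).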

Compound 3, half-maximal inhibitory concentration: 8150 nM
The estimate for compound 3 lay 1.7-fold (0.23 log units) above the measured number, and the stated range covers the measured number.
By their numbers in this assay, from the lowest: compounds 3, 1 and 2 (each within the scatter of the next).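

Replacing 4-hydroxy-3-methoxyphenyl with 4-methoxyphenyl in this assay gives a 1.5-fold lower number from compound 1 to compound 3 (0.19 log units; within the scatter), and hydrogen in place of methoxy on an aromatic carbon gives a 1.8-fold lower number from compound 2 to compound 3 (0.24 log units; within the scatter). Among these compounds, then, the hydroxy can go entirely, rather than only carry a methyl, and the number still stays within the scatter. No measurement here offers an explanation for this result. Still open, on these data alone, is whether an amine, a carboxylic acid or a fluorine on this ring would move the number beyond the scatter.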